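This account rests on a few compounds, and the source may have more. Where it says the series, first, only, none or still open, it means among the compounds named here.

Compound 1 `O=C(Nc1ccc(F)cc1)c1c(NO)cc(-c2cccs2)oc1=O`: in an ADME assay on Huh-7 cells (Homo sapiens) for cytotoxicity, with a stated time of 3 days (on this read-out higher numbers stand for lower toxicity in this test and lower numbers for higher toxicity in this test), compound 1 gives > 20000 nM, which is a limit of the assay rather than a number.
Compound 2 `Cc1ccccc1NC(=O)c1c(NO)cc(-c2cccs2)oc1=O`: in this assay compound 2 gives > 20000 nM, likewise a limit of the assay.

Going by the values given here, compound 2 therefore stands at the limit of this assay, and so does compound 1; the only measured step, a step that the two limits leave unreadable from compound 1 to compound 2, cannot be read, since both of its ends sit at the same limit, as stated in the limit of > 20000 nM in this assay, at which 2 of the 2 values shown sit. The account follows the change from compound 2 to compound 3 `Nc1ccccc1NC(=O)c1c(NO)cc(-c2cccs2)oc1=O`, where the difference is amino in place of methyl on an aromatic carbon, ortho to a large group. Among the compounds with values here, the one measured step that bears on an exchange of the group on the amide-type nitrogen is the step from compound 1 to compound 2, and its size is unreadable, so no measured step tells the size of the coming step in this assay, and no direction beyond the scatter can be claimed. Given that compound 2 sits at the limit, compound 3 is expected to remain near or above it, with an estimated step that the limit leaves unreadable from compound 2 to compound 3. Compound 3 is accordingly estimated at 30000 nM in this assay, with a range from 12000 nM to 80000 nM.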

Compound 3, half-maximal cytotoxic concentration: > 20000 nM
Compound 3: a limit, no number; the forecaster's own chance of this, stated with the estimate: 75%; the middle value is on the limit's open side.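

Compound 3 gives only a limit of the assay in this assay, as do compound 1 and compound 2, so none of the steps among these three compounds can be read: the limit of > 20000 nM in this assay, at which 3 of the 3 values shown sit.

The compounds shown leave open how far each lies beyond that limit, and whether exchanging the group on the amide-type nitrogen changes the half-maximal cytotoxic concentration at all.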